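Swapping the Furan Amide for a Chloromethylpyridine

The source may report more compounds than this note shows. Statements on the series, on what has been measured and on what is new or still open speak of the compounds shown alone.

Compound 1 `CCCCc1ccc(C(=O)Nc2ccc(S(=O)(=O)NC3CCN(C(=O)CCC)CC3)c3ccccc23)cc1`: 15.3 nM
Compound 2 `CCCC(=O)N1CCC(NS(=O)(=O)c2ccc(NC(=O)c3cc(C)oc3C(F)(F)F)c3ccccc23)CC1`: 46.9 nM

In an in vitro functional assay on CHO/Galpha16 cells for antagonist activity at C-C chemokine receptor type 8 (Homo sapiens), read by FLIPR (on this read-out lower numbers stand for stronger inhibition and higher numbers for weaker inhibition), compound 2 has the higher of the two numbers, its nearest neighbour being compound 1, which it reaches through a 3.1-fold higher number from compound 1 to compound 2 (0.49 log units; beyond the scatter). Compound 3 `CCCC(=O)N1CCC(NS(=O)(=O)c2ccc(NC(=O)c3cc(C)nc(Cl)c3)c3ccccc23)CC1` differs from compound 2 by 2-chloro-6-methylpyridin-4-yl in place of 5-methyl-2-(trifluoromethyl)furan-3-yl on a carbonyl carbon. Going by the values given here, only one measured step touches this position, and because a 3.1-fold higher number from compound 1 to compound 2 (0.49 log units; beyond the scatter) ran from a six-membered aromatic ring to a five-membered one, compound 3, which brings back a six-membered ring, is expected to move modestly the other way, a 1.6-fold lower number from compound 2 to compound 3 (0.19 log units; within the scatter). Compound 3 is therefore estimated at 30 nM, within a range from 10 nM to 100 nM.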

Compound 3, half-maximal inhibitory concentration: 43.9 nM
The estimate for compound 3 lay 1.5-fold (0.17 log units) below the measured number; the measured number falls inside the stated range.
By their numbers in this assay, from the lowest: compound 1; then compounds 3 and 2 (each within the scatter of the next).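

In this assay, the 2-chloro-6-methylpyridin-4-yl group on the carbonyl carbon and the 5-methyl-2-(trifluoromethyl)furan-3-yl group cannot be told apart, with a 1.1-fold lower number from compound 2 to compound 3 (0.03 log units; within the scatter). Returning to a six-membered aromatic ring therefore does not by itself restore the level of compound 1, as a 2.9-fold higher number from compound 1 to compound 3 (0.46 log units; beyond the scatter) shows. No available evidence bears on this result. The compounds shown leave open whether the gap to compound 1 follows the butyl chain or the phenyl ring. An unsubstituted phenyl or a butyl-bearing pyridine would separate the two.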